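The source may hold more compounds than are shown below. What is called first, only, known or untested is meant among the compounds shown, and "the series" means these compounds.

Working notes on the series.

Compound 1 `Clc1cccc(-c2ccc(-c3ccc(-c4nc5ccccc5[nH]4)cc3)cc2)c1` is the reference point: in a functional assay on HOP-62 cells (Homo sapiens) for inhibition, read by sulforhodamine B assay (on this read-out higher numbers stand for weaker inhibition of growth and lower numbers for stronger inhibition of growth), compound 1 gives 100000 nM. Two single changes on this core have been measured. Compound 2 `COc1ccc(-c2ccc(-c3ccc(-c4nc5ccccc5[nH]4)cc3)cc2)cc1OC` carries the change 3,4-dimethoxyphenyl in place of 3-chlorophenyl on an aromatic carbon and in this assay compound 2 gives 4200 nM, a step of a 24-fold lower number from compound 1 to compound 2 (1.38 log units; beyond the scatter). Compound 3 `Oc1cccc2[nH]c(-c3ccc(-c4ccc(-c5cccc(Cl)c5)cc4)cc3)nc12` carries the change hydroxy in place of hydrogen on an aromatic carbon and in this assay compound 3 gives 2260 nM, a step of a 44-fold lower number from compound 1 to compound 3 (1.65 log units; beyond the scatter). Compound 2 and compound 3 lie within the scatter of each other, so no order between them is claimed.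

Compound 4 `COc1ccc(-c2ccc(-c3ccc(-c4nc5c(O)cccc5[nH]4)cc3)cc2)cc1OC` has not been measured in this assay. It differs from compound 3 by 3,4-dimethoxyphenyl in place of 3-chlorophenyl on an aromatic carbon. For the measured compounds named here, this is the same change as the one from compound 1 to compound 2, where the step was a 24-fold lower number from compound 1 to compound 2 (1.38 log units; beyond the scatter); the place lines of the two changes read the same word for word. The cores of the two pairs differ by hydroxy in place of hydrogen on an aromatic carbon.

Expectation for compound 4 in this assay: the step is expected to run in the same direction as the earlier one but smaller, an estimated 5.7-fold lower number from compound 3 to compound 4 (0.75 log units; beyond the scatter), because the earlier step of a 24-fold lower number from compound 1 to compound 2 (1.38 log units; beyond the scatter) started from a compound 1 value of 100000 nM while compound 3 already stands at 2260 nM, and the two changes are not known from these data to add fully. The number for compound 4 is expected near 400 nM, with a plausible range from 80 nM to 2000 nM.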

Compound 4, concentration for 50% growth inhibition: 2210 nM
For compound 4 the middle estimate is 5.5-fold (0.74 log units) below the measured one, outside the stated range (above it).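

In this assay the change to 3,4-dimethoxyphenyl from 3-chlorophenyl does not carry over from the core of compound 1 to the core of compound 3, where the step is a 1.0-fold lower number from compound 3 to compound 4 (0.01 log units; within the scatter), and the two steps differ: the same change on two cores in this assay, a 24-fold lower number (1.38 log units; beyond the scatter) from compound 1 to compound 2 and a 1.0-fold lower number (0.01 log units; within the scatter) from compound 3 to compound 4, 23-fold (1.37 log units) apart, beyond the scatter of two such steps

The hydroxy change fails to carry over in the same way, with a step of a 1.9-fold lower number from compound 2 to compound 4 (0.28 log units; within the scatter) once 3,4-dimethoxyphenyl is in place: the same change on two cores in this assay, a 44-fold lower number (1.65 log units; beyond the scatter) from compound 1 to compound 3 and a 1.9-fold lower number (0.28 log units; within the scatter) from compound 2 to compound 4, 23-fold (1.37 log units) apart, beyond the scatter of two such steps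

So in these four compounds either change alone accounts for the whole step from compound 1 and the two together add nothing measurable, but a single set of four compounds in this assay does not show why this is so or whether it holds for other groups on this core.

As far as these compounds go, it remains open whether the level shared by compound 2, compound 3 and compound 4 can be passed on this core at all, for instance with an amine or a carboxylic acid in place of the hydroxy. From the compounds shown here alone, it is equally open whether a single methoxy group, or a longer chain in place of the methoxy groups of 3,4-dimethoxyphenyl, would behave as 3,4-dimethoxyphenyl does on the two cores.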